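Working notes: aryl swap on the ring amine

The compounds below may be only part of what the source reports. "The series", "measured", "known", "first", "only" and "open" are said of these compounds alone.

Measured so far:
compound 1 `CC(=O)N1CCC(C(=O)N(CCCN2CCC(Oc3ccccc3)CC2)c2ccc(C)c(Cl)c2)CC1` — > 56600 nM
compound 2 `CCN(Cc1ccccc1)C(=O)C1CCN(CCCN(C(=O)C2CCN(C(C)=O)CC2)c2ccc(C)c(Cl)c2)CC1` — 83.9 nM
compound 3 `CC(=O)N1CCC(C(=O)N(CCCN2CCN(Cc3ccccc3)CC2)c2ccc(C)c(Cl)c2)CC1` — 101000 nM

In an ADME assay (Homo sapiens) for cytotoxicity (on this read-out higher numbers stand for lower toxicity in this test and lower numbers for higher toxicity in this test), compound 3 holds the highest of the two numbers given; compound 2 sits far lower. For compound 1 the figure is a limit of the assay rather than a number (the limit of > 56600 nM in this assay, at which 1 of the 3 values shown sits). Among the compounds with values here, the one measured step, an at least 670-fold lower number from compound 1 to compound 2 (2.82 log units; beyond the scatter), touches a different part of the core and so does not bear on the change at hand.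

Compound 4 `CC(=O)N1CCC(C(=O)N(CCCN2CCN(c3ccccn3)CC2)c2ccc(C)c(Cl)c2)CC1` differs from compound 3 by pyridin-2-yl in place of benzyl on an amine nitrogen in a ring. Within the data shown here, with no step at this position to draw on, no change beyond the scatter is expected for compound 4; the expected step is a 1.7-fold lower number from compound 3 to compound 4 (0.23 log units; within the scatter). Compound 4 is therefore estimated at 60000 nM, within 15000 nM to 150000 nM.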

Compound 4, half-maximal cytotoxic concentration: > 58300 nM
Compound 4: no number, only a limit (the forecaster's own chance of this, stated with the estimate: 30%); the middle value is on the limit's open side.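

Compound 4 gives only a limit of the assay, so no step from compound 3 to compound 4 can be read: the limit of > 58300 nM in this assay, at which 1 of the 4 values shown sits.

The compounds shown leave open whether pyridin-2-yl in place of benzyl shifts the read-out in this assay at all.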